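Methylsulfanyl in Place of Bromo: An Expected Small Step

This account rests on a few compounds, and the source may have more. Where it says the series, first, only, none or still open, it means among the compounds named here.

Of the compounds shown here, two have so far been measured in an assay on cells for inhibition of sodium- and chloride-dependent glycine transporter 1 (Homo sapiens); on this read-out higher numbers stand for an effect only at larger amounts of compound and lower numbers for an effect already at smaller amounts. Compound 1 `CN1CCCC(NC(=O)c2ccc(C(F)(F)F)cc2C(F)(F)F)(c2ccccc2)C1` gives 540 nM in this assay, while compound 2 `CN1CCCC(NC(=O)c2ccc(C(F)(F)F)cc2Br)(c2ccccc2)C1` gives 300 nM. Among the measured compounds shown here, the single measured step, a 1.8-fold lower number from compound 1 to compound 2 (0.26 log units; within the scatter), exchanges trifluoromethyl for bromo on an aromatic carbon and lies within the scatter. Compound 2 thus holds the lower of the two numbers shown, with compound 1 as its only neighbour, and the gap between them is not a real difference. Compound 3 `CSc1cc(C(F)(F)F)ccc1C(=O)NC1(c2ccccc2)CCCN(C)C1` has not yet been measured. It differs from compound 2 in one place: methylsulfanyl in place of bromo on an aromatic carbon. For the measured compounds named here, only the step from compound 1 to compound 2 bears on this change, and since that step stayed within the scatter, there is no ground to expect a move beyond the scatter in this assay in either direction. For compound 3 the value in this assay is therefore estimated at 300 nM, with a range from 120 nM to 750 nM. The expected step is no change at the digits printed from compound 2 to compound 3 (within the scatter), a change that would stay inside the usual scatter.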

Compound 3, half-maximal effective concentration: 67 nM
Compound 3: the middle estimate sits 4.5-fold (0.65 log units) above what was measured; the whole stated range lies above it.
By their numbers in this assay, from the lowest: compound 3; then compounds 2 and 1 (each within the scatter of the next).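

In this assay, the exchange of bromo for methylsulfanyl on this aromatic carbon, ortho to a large group and meta to a trifluoromethyl group, gives a 4.5-fold lower number from compound 2 to compound 3 (0.65 log units; beyond the scatter). This shows that the number in this assay can move with the group at this position, which the earlier pair, with its step inside the scatter, did not show. Methylsulfanyl also stands apart from trifluoromethyl at the same carbon, with an 8.1-fold lower number from compound 1 to compound 3 (0.91 log units; beyond the scatter), so compound 3 holds the lowest number of the three, and the two earlier compounds stay within the scatter of each other; the data shown offer no explanation for this drop.

Still open, going by these compounds, is whether the sulfur or its methyl accounts for the step, a question that a methoxy group or a free thiol at this carbon would help to separate. On these data alone, it is equally open how far the trend extends to a longer chain such as ethylsulfanyl or to methylsulfonyl, and whether the step would hold with another group in place of the trifluoromethyl group that stays in all three compounds.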